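The compounds below may be only part of what the source reports. "The series", "measured", "known", "first", "only" and "open" are said of these compounds alone.

The study concerns four compounds built around a quinazoline-type scaffold carrying an arylsulfonamide on a side chain, and tested for antiproliferative activity in a functional assay on A549 cells (Homo sapiens) for antiproliferative activity, read by MTT assay, with a stated time of 72 h; a lower number here means a stronger inhibitor, a higher number a weaker inhibitor. Compound 1 `COc1cc2ncnc(Nc3ccc(Cl)cc3)c2cc1OCCCCC(=O)Nc1ccc(S(N)(=O)=O)cc1` and compound 2 `COc1cc2ncnc(Nc3ccccc3)c2cc1OCCCCC(=O)Nc1ccc(S(N)(=O)=O)cc1` share a core that joins the sulfonamide through a five-carbon amide linker. Compound 3 `NS(=O)(=O)c1ccc(NC(=S)Nc2ccc3ncnc(Nc4cccc(C(F)(F)F)c4)c3c2)cc1` joins it instead through a thiourea; how this core differs from that of compound 2 is not broken down here.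

In this assay compound 1 reaches only the limit of the assay, > 40000 nM. Compound 2 likewise reaches only the limit, > 40000 nM. For the measured compounds named here, compound 3 gives 10100 nM in this assay, the only measured number among the three.

The change from compound 2 to compound 1 is chloro in place of hydrogen on an aromatic carbon, and it yields a step that the two limits leave unreadable from compound 2 to compound 1, unreadable because of the limit of > 40000 nM in this assay, at which 2 of the 3 values shown sit.

Compound 4 `NS(=O)(=O)c1ccc(NC(=S)Nc2ccc3ncnc(Nc4ccc(Cl)c(C(F)(F)F)c4)c3c2)cc1` has not yet been measured. It differs from compound 3 by chloro in place of hydrogen on an aromatic carbon. This is the same kind of change as that from compound 2 to compound 1, but not the same: in compound 4 the entering chloro also sits ortho to a trifluoromethyl group, whereas in compound 1 it sits only para to a large group. Since the earlier step gives no readable size, the expectation for compound 4 rests on the value of compound 3 alone, 10100 nM, with a step of a 1.4-fold lower number from compound 3 to compound 4 (0.16 log units; within the scatter) that is expected to lie within the usual scatter. Compound 4 is therefore estimated at 7000 nM, between 2500 nM and 25000 nM.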

Compound 4, half-maximal inhibitory concentration: 4500 nM
Compound 4: middle estimate off by 1.6-fold (0.19 log units), on the high side; low and high end bracket the measured number.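

On the thiourea-linked core in this assay, chloro in place of hydrogen on an aromatic carbon gives a 2.2-fold lower number from compound 3 to compound 4 (0.35 log units; beyond the scatter), a modest gain and the only readable size for this change in the series. On the core of compound 2, which carries the five-carbon amide linker, the same change yields no size that can be set beside it, because neither of its two compounds gives a number: the limit of > 40000 nM in this assay, at which 2 of the 4 values shown sit. The result therefore shows that the change can lower the number on one core, but not that it carries from one core to the other, and the comparison is further limited by the place of the chloro, which in compound 4 is ortho to a trifluoromethyl group and in compound 1 only para to a large group.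

The compounds shown leave open whether chloro would give a step of similar size on the thiourea-linked core without the trifluoromethyl group, and whether the amide-linked core would leave the limit of the assay if it carried the 4-chloro-3-(trifluoromethyl)phenyl group. They also leave open whether a bromo, a methyl or an amine at the place taken by chloro would go the same way.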